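A few compounds are considered here, and "the series" means these few. Any claim that something is new, unique, unknown or untested is made for them only; others in the source may bear on it.

Measured so far:
Compound 1 `O=C(O)C[C@H](O)C[C@H](O)CCn1c(C(F)(F)F)nc(-c2ccccc2)c1-c1ccc(F)cc1` gives 31 nM in an assay on microsomes from liver for inhibition of 3-hydroxy-3-methylglutaryl-coenzyme A reductase (Rattus norvegicus); a lower number here means a stronger inhibitor, a higher number a weaker inhibitor.
Compound 2 `O=C(O)C[C@H](O)C[C@H](O)CCn1c(C(F)(F)F)nc(-c2cccnc2)c1-c1ccc(F)cc1` gives 66 nM in this assay.
Compound 3 `O=C(O)C[C@H](O)C[C@H](O)CCn1c(C(F)(F)F)nc(-c2ccc(F)cc2)c1-c1cccc(Cl)c1` gives 41 nM in this assay.

Compound 3 stands second highest of the three numbers, within the scatter of both compound 1 and compound 2. Compound 4 `O=C(O)C[C@H](O)C[C@H](O)CCn1c(C(F)(F)F)nc(-c2ccc(F)cc2)c1-c1cccs1` differs from it by thiophen-2-yl in place of 3-chlorophenyl on an aromatic carbon. Within the data shown here, no measured step covers this exact exchange. Among the measured compounds shown here, the only step that bears on it is a 2.1-fold higher number from compound 1 to compound 2 (0.33 log units; beyond the scatter), where an aromatic ring of carbon only gave way to a ring with one hetero atom at a different site of the core. A similar modest weakening is therefore expected here. Compound 4 is expected to give about 60 nM in this assay, between 25 nM and 150 nM, a step of a 1.5-fold higher number from compound 3 to compound 4 (0.17 log units; within the scatter).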

Compound 4, half-maximal inhibitory concentration: 215 nM
Compound 4: the middle estimate sits 3.6-fold (0.55 log units) below what was measured; the measured number lies above the stated range.
By their numbers in this assay, from the lowest: compounds 1, 3 and 2 (each within the scatter of the next, the first and the last beyond it); then compound 4.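

At the position next to the ring nitrogen, in this assay, thiophen-2-yl in place of 3-chlorophenyl gives a 5.2-fold higher number from compound 3 to compound 4 (0.72 log units; beyond the scatter) and places compound 4 beyond the scatter of all three earlier compounds. Among these compounds, this is the first reading at this position, and it shows that the number here depends on which aromatic ring sits there. No measurement at hand accounts for the step.

The exchange alters ring size, the hetero atom and the chlorine at once, and these cannot be separated. On these data alone, how furan-2-yl or cyclohexyl would fare at this position remains open.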